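The source may report more compounds than this note shows. Statements on the series, on what has been measured and on what is new or still open speak of the compounds shown alone.

Measured so far in a functional assay, read by spectrophotometry, with a stated time of 30 min, tested at 150 ug/mL; on this read-out lower numbers stand for a weaker effect and higher numbers for a stronger effect at the one concentration tested: compound 1 `CN1CCN(CC(=O)Nc2nc3ccccc3[nH]2)CC1` gives 54.3%; compound 2 `O=C(CN1CCN(c2ccccc2F)CC1)Nc1nc2ccccc2[nH]1` gives 56.6%; compound 3 `O=C(CN1CCN(c2ccccn2)CC1)Nc1nc2ccccc2[nH]1` gives 69.1%.

Compound 2 stands second highest of the three numbers, though its gap to compound 1 lies within the scatter; compound 3 alone sits beyond it, a number 12.5 percentage points higher from compound 2 to compound 3 (beyond the scatter). Compound 4 `COc1ccc(N2CCN(CC(=O)Nc3nc4ccccc4[nH]3)CC2)cc1` differs from compound 2 at the ring amine: 4-methoxyphenyl in place of 2-fluorophenyl on an amine nitrogen in a ring. Among the measured compounds shown here, two measured steps bear on changing the group at this position. a number 2.3 percentage points higher from compound 1 to compound 2 (within the scatter); a number 14.8 percentage points higher from compound 1 to compound 3 (beyond the scatter). For the measured compounds named here, only the pyridin-2-yl exchange moved this assay beyond the scatter, and an aryl-for-aryl swap has no direct precedent here. A step within the scatter is expected, a number 1.4 percentage points higher from compound 2 to compound 4 (within the scatter). Compound 4 is accordingly estimated at 58% in this assay, range 45% to 72%.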

Compound 4, a percentage reported as activity, at one concentration (the size of the read-out at that concentration, not a potency): 53.2%
Estimate against measurement, compound 4: 4.8 percentage points above, within the range that was stated.
By their numbers in this assay, from the lowest: compounds 4, 1 and 2 (each within the scatter of the next); then compound 3.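

In this assay the 4-methoxyphenyl group on the ring amine nitrogen stays within the scatter of both 2-fluorophenyl (a number 3.4 percentage points lower from compound 2 to compound 4 (within the scatter)) and methyl (a number 1.1 percentage points lower from compound 1 to compound 4 (within the scatter)). The pyridin-2-yl group of compound 3 now stands apart from a second carbon-only aryl group (a number 15.9 percentage points lower from compound 3 to compound 4 (beyond the scatter)), so among these four groups it alone separates beyond the scatter. No measurement at hand accounts for this separation.

Open, as far as these compounds go, is whether pyridin-3-yl or pyrimidin-2-yl on the same nitrogen would stay with compound 3 or fall in with compound 4.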